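A few compounds are considered here, and "the series" means these few. Any claim that something is new, unique, unknown or untested is made for them only; others in the source may bear on it.

Measured compounds:
- compound 1, `CCOC(=O)C1=C(C)NC(C)=C(C(=O)OCC)C1c1ccc(OCC(=O)Nc2c(C)cccc2C)cc1`: 26.3%
- compound 2, `CCOC(=O)C1=C(C)NC(C)=C(C(=O)OCC)C1c1ccc(OCC(=O)Nc2ccc(C)cc2)cc1`: 55.1%
- compound 3, `CCOC(=O)C1=C(C)NC(C)=C(C(=O)OCC)C1c1ccc(OCC(=O)NNC(=O)c2ccc(C)cc2)cc1`: 35.9%

All three share one core and differ only in the group on the amide-type nitrogen. In a functional assay on the whole organism (strain Wistar) for inhibition, with Rattus norvegicus as the target, read by paw edema, with stated times of 30 min and 1 h, at a dose of 20 mg/kg (a lower number here means less inhibition, a higher number more inhibition at the dose given (going by the name of the read-out)), compound 3 gives 35.9%, the second highest of the three numbers. One step is a number 9.6 percentage points higher from compound 1 to compound 3 (within the scatter), so the two cannot be told apart, while the other is a number 19.2 percentage points lower from compound 2 to compound 3 (beyond the scatter), which sets the two apart.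

Compound 4, `CCOC(=O)C1=C(C)NC(C)=C(C(=O)OCC)C1c1ccc(OCC(=O)NNC(=O)c2ccccc2)cc1`, is compound 3 with the change (hydrogen in place of methyl on an aromatic carbon). Among the compounds with values here, no measured step moves the same part of the structure: the steps of a number 28.8 percentage points higher from compound 1 to compound 2 (beyond the scatter) and a number 19.2 percentage points lower from compound 2 to compound 3 (beyond the scatter) rearrange the whole group on the nitrogen, not a single methyl at the far end of it. They show that replacing the 2,6-dimethylphenyl or the 4-methylphenyl changes the read-out modestly, but a single methyl to hydrogen on an aromatic carbon is a much smaller change. The expected step is therefore a number 2.9 percentage points lower from compound 3 to compound 4 (within the scatter), which is within the scatter. Compound 4 is expected to give 33% in this assay, with a range from 18% to 50%.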

Compound 4, a percentage reported as inhibition, in the whole organism at one dose (the size of the read-out at that dose, not a potency): 29.5%
Compound 4: middle estimate off by 3.5 percentage points, on the high side, and the stated range covers the measured number.
By their numbers in this assay, from the lowest: compounds 1, 4 and 3 (each within the scatter of the next); then compound 2.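

Taking the one methyl off the aromatic ring is the first change here confined to this single position, and in this assay it gives a number 6.4 percentage points lower from compound 3 to compound 4 (within the scatter), so in this pair the methyl can be lost without a change that stands out from the scatter. Compound 4 still differs clearly from the 4-methylphenyl amide, with a number 25.6 percentage points lower from compound 2 to compound 4 (beyond the scatter), but it cannot be told apart from the 2,6-dimethylphenyl amide, with a number 3.2 percentage points higher from compound 1 to compound 4 (within the scatter), so among these compounds the larger step comes from swapping the whole group on the nitrogen. No measurement at hand gives a reason for any of these steps.

Going by these compounds, whether a methoxy group, a chlorine atom or a carboxylic acid at this ring position would move the number remains open. Also open, on these data alone, is whether the same change from methyl to hydrogen would have as small an effect on compound 2.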